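The source may hold more compounds than are shown below. What is called first, only, known or untested is meant among the compounds shown, and "the series" means these compounds.

Three compounds have been measured in a functional assay on KG-1a cells (Homo sapiens) for inhibition, read by MTT assay, with a stated time of 72 h; a lower number here means a stronger inhibitor, a higher number a weaker inhibitor:

compound 1 `Cc1ccc(-c2nnc(-c3cccnc3)o2)cc1Nc1nccc(-c2cccnc2)n1`, > 30000 nM, which is a limit of the assay and not a number
compound 2 `Cc1nnc(-c2ccc(C)c(Nc3nccc(-c4cccnc4)n3)c2)o1`, 18000 nM
compound 3 `Cc1ccc(-c2nnc(-c3ccc(F)c(C(F)(F)F)c3)o2)cc1Nc1nccc(-c2cccnc2)n1`, > 30000 nM, again a limit of the assay rather than a number

Compound 3 thus sits at the limit of > 30000 nM in this assay, at which 2 of the 3 values shown sit. Its value in this assay is not pinned down, so the step from compound 1 to compound 3 is a step that the two limits leave unreadable from compound 1 to compound 3, while from compound 2 the step is an at least 1.6-fold higher number from compound 2 to compound 3 (0.22 log units; that floor lies within the scatter). None of the three compounds gives a number that lies far from that limit; all are weak inhibitors here.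

Compound 4 `Cc1ccc(-c2nnc(-c3ccc(CN4CCN(CCN=C=S)CC4)c(C(F)(F)F)c3)o2)cc1Nc1nccc(-c2cccnc2)n1` differs from compound 3 in one place: a group of 12 heavy atoms (8 carbon, 3 nitrogen, 1 sulfur; one six-membered non-aromatic ring with 2 hetero atoms) in place of one fluorine atom, on an aromatic carbon. Among the compounds with values here, no measured step in this set replaces a fluorine with a group of this kind, so the measured steps give only a weak guide: the earlier changes at this part of the molecule, from pyridin-3-yl or methyl to the fluorinated aryl, left compound 3 at the limit. On that basis compound 4 is expected to stay in the same weak region, with an at least 1.5-fold lower number from compound 3 to compound 4 (0.17 log units; that floor lies within the scatter) reflecting mainly uncertainty rather than a firm direction. The estimate for compound 4 in this assay is 20000 nM, with a range from 5000 nM to 60000 nM.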

Compound 4, half-maximal inhibitory concentration: 940 nM
Estimate against measurement, compound 4: 21-fold (1.33 log units) above; the whole stated range lies above it.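

In this assay, replacing the fluoro group, ortho to a trifluoromethyl group, with the group of 12 heavy atoms gives an at least 31-fold lower number from compound 3 to compound 4 (1.50 log units; beyond the scatter). Within the data shown here, the earlier compounds showed only that swapping one whole group on the oxadiazole-free side of the comparison for another left the values weak; this step shows that a single substituent on this aromatic ring can move the value far beyond the scatter, so this position is open to a large group and can matter greatly in these cells. Compound 4, at 940 nM, stands well clear of the weak region where the other compounds lie. Compound 1 and compound 3 remain at a limit of the assay, which is not a number: the limit of > 30000 nM in this assay, at which 2 of the 4 values shown sit.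

The compounds shown do not separate the contribution of the six-membered ring from that of the sulfur-bearing end of the chain, since both enter together in one change. A close relative ending in a simple amine or a hydroxyl group in place of that sulfur-bearing end would be needed to say which part carries the step.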